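A few compounds are considered here, and "the series" means these few. Any claim that something is new, unique, unknown or untested is made for them only; others in the source may bear on it.

The series is built on a dodecylamine-type core carrying small amine-bearing head groups, and every member is read in a functional assay on HL-60 cells (Homo sapiens) for activation; on this read-out lower numbers stand for an effect already at smaller amounts and higher numbers for an effect only at larger amounts of compound. Compound 1 `CCCCCCCCCCCCNC(=O)C(N)CN` gives 2510 nM, compound 2 `CCCCCCCCCCCCNCC(N)CCCN` gives 1000 nM, and compound 3 `CCCCCCCCCCCCNC(=O)C(N)CCCN` gives 2510 nM. Compound 3 therefore stands level with compound 1, the two of them the highest numbers among the three, while compound 2 sits a step lower. Going by the values given here, the only single-point change among the measured compounds, no change at the digits printed from compound 1 to compound 3 (within the scatter), shows that lengthening the amine-bearing side chain leaves the read-out unchanged.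

Compound 4 `CCCCCCCCCCCCNC(=O)CNC(=O)CN` has not yet been measured. It differs from compound 3 in that ((((aminomethyl)carbonyl)amino)methyl in place of 1,4-diaminobutyl on a carbonyl carbon). Among the compounds with values here, no measured step covers this exact exchange; the one step available, from compound 1 to compound 3, only tells that the length of an amine-bearing chain on the head group made no difference, and the pair of compound 2 and compound 3 shows that the head group itself can shift the number moderately. Compound 4 is accordingly expected to land near compound 3 or somewhat above it, with an estimated step of a 1.6-fold higher number from compound 3 to compound 4 (0.20 log units; within the scatter). The estimate for compound 4 in this assay is 4000 nM, within a range from 1500 nM to 12000 nM.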

Compound 4, half-maximal effective concentration: 5010 nM
Beside the measured number, compound 4's estimate is 1.3-fold (0.10 log units) below it; low and high end bracket the measured number.
By their numbers in this assay, from the lowest: compound 2; then compounds 1, 3 and 4 (each within the scatter of the next).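

In this assay, the group on the carbonyl carbon whose other neighbour is an amide-type nitrogen now holds a carbonyl within its chain: (((aminomethyl)carbonyl)amino)methyl in place of 1,4-diaminobutyl gives one step (a 2.0-fold higher number from compound 3 to compound 4 (0.30 log units; within the scatter)), and the same group in place of 1,2-diaminoethyl gives another (a 2.0-fold higher number from compound 1 to compound 4 (0.30 log units; within the scatter)). The earlier step had varied only the length of a diamine-bearing group, whereas these two show that exchanging such a group for one with a carbonyl and a second amide-type nitrogen also stays within the scatter, at equal printed counts of hydrogen-bond donors and acceptors for 1,4-diaminobutyl and the entering group. Nothing available here explains why these head groups read alike.

From the compounds shown here alone, it remains open whether a carboxylic acid or a guanidine in place of these amine-bearing groups on the carbonyl carbon would move the number beyond the scatter. Also open, going by these compounds, is how a tetradecyl chain in place of the dodecyl chain of the shared core would read with the (((aminomethyl)carbonyl)amino)methyl group in place.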